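From Piperidinyl to Methylamino: Expecting Compound 4

The compounds below may be only part of what the source reports. "The series", "measured", "known", "first", "only" and "open" are said of these compounds alone.

Of the compounds shown here, three have been measured in a functional assay for inhibition, with Homo sapiens as the target; a lower number here means a stronger inhibitor, a higher number a weaker inhibitor. Compound 1 `c1coc(-c2ccnc(Nc3ccc(-n4ccnc4)cc3)n2)c1` gives 2200 nM, compound 2 `COc1cccc(Nc2nccc(-c3cccs3)n2)c1` gives 900 nM, and compound 3 `CC1CCN(c2ccc(Nc3nccc(-c4cccnc4)n3)cc2)CC1` gives 500 nM. Compound 3 thus stands at the lowest of the three numbers, though compound 2 lies within the usual scatter of it, while compound 1 lies beyond that scatter. Compound 4 `CNc1ccc(Nc2nccc(-c3cccnc3)n2)cc1` is not yet measured. It differs from compound 3 in one place: methylamino in place of 4-methylpiperidin-1-yl on an aromatic carbon. Among the measured compounds shown here, no pair of measured compounds isolates this change, so its effect is not known from the numbers at hand. The step of a 2.0-fold higher number from compound 3 to compound 4 (0.30 log units; within the scatter) is expected to be modest, toward a higher number, and possibly within the scatter. Compound 4 is therefore estimated at 1000 nM, with a range from 300 nM to 3500 nM.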

Compound 4, half-maximal inhibitory concentration: 2100 nM
Estimate against measurement, compound 4: 2.1-fold (0.32 log units) below; measured number inside the range.
By their numbers in this assay, from the lowest: compounds 3 and 2 (each within the scatter of the next); then compounds 4 and 1 (each within the scatter of the next).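

In this assay, among the compounds shown here, methylamino in place of 4-methylpiperidin-1-yl on this aromatic carbon gives a 4.2-fold higher number from compound 3 to compound 4 (0.62 log units; beyond the scatter), the first change at this position that can be read on its own. The position therefore does not tolerate every group: exchanging the ring for the open methylamino weakens inhibition. No measurement at hand accounts for this step.

On these data alone, whether morpholine, piperazine or dimethylamino at this place would stay close to compound 3 remains open. So does whether the ring itself or its 4-methyl group matters.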